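A few compounds are considered here, and "the series" means these few. Any claim that something is new, unique, unknown or untested is made for them only; others in the source may bear on it.

Working notes on the amine series. Compound 1 `O=C(CCc1ccc(C(F)(F)F)cc1)Nc1ccc2nc(N3CCC3)ccc2c1` carries azetidin-1-yl and in a functional assay on HEK293 cells for activation of melanin-concentrating hormone receptor 1 (Rattus norvegicus), read by inositol phosphate accumulation (a lower number here means that less compound is needed, a higher number that more compound is needed for the effect), gives 56 nM. Compound 2 `CN(c1ccc2cc(NC(=O)CCc3ccc(C(F)(F)F)cc3)ccc2n1)C1CCCC1` carries cyclopentyl(methyl)amino and gives 350 nM, second highest of the three numbers, with compound 3 `O=C(CCc1ccc(C(F)(F)F)cc1)Nc1ccc2nc(N3CCCCCC3)ccc2c1`, which carries azepan-1-yl, at 1800 nM as the nearest neighbour and compound 1 as the furthest. The measured steps are a 6.3-fold higher number from compound 1 to compound 2 (0.80 log units; beyond the scatter), a 32-fold higher number from compound 1 to compound 3 (1.51 log units; beyond the scatter) and a 5.1-fold higher number from compound 2 to compound 3 (0.71 log units; beyond the scatter): each enlargement of the amine on the shared core has raised the number.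

Compound 4 `O=C(CCc1ccc(C(F)(F)F)cc1)Nc1ccc2nc(N3CCCCC3)ccc2c1` is not yet measured. It differs from compound 2 as follows: piperidin-1-yl in place of cyclopentyl(methyl)amino on an aromatic carbon. The two steps that bear on it are those from compound 1 to compound 2 and from compound 2 to compound 3, both modest and both upward; piperidin-1-yl sits between azetidin-1-yl and azepan-1-yl by ring count, and the leaving cyclopentyl(methyl)amino is itself of middling size. An expected step in this assay of a 1.3-fold higher number from compound 2 to compound 4 (0.11 log units; within the scatter) therefore follows, small and not clearly beyond the scatter. Compound 4 is expected to give 450 nM, within 130 nM to 1500 nM.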

Compound 4, half-maximal effective concentration: 110 nM
For compound 4 the middle estimate is 4.1-fold (0.61 log units) above the measured one; the measured number lies below the stated range.
By their numbers in this assay, from the lowest: compounds 1 and 4 (each within the scatter of the next); then compound 2; then compound 3.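

In this assay, among the compounds shown here, the position next to the ring nitrogen takes piperidin-1-yl on a par with azetidin-1-yl (a 2.0-fold higher number from compound 1 to compound 4 (0.29 log units; within the scatter)), so the rise with ring size seen in the earlier compounds does not proceed evenly. Most of that rise lies in the single change of ring from piperidin-1-yl to azepan-1-yl (a 16-fold lower number from compound 3 to compound 4 (1.21 log units; beyond the scatter)). The ring also compares well with the open-chain amine of similar size (a 3.2-fold lower number from compound 2 to compound 4 (0.50 log units; beyond the scatter)), and no measurement at hand accounts for any of these steps.

Pyrrolidine on this carbon would complete the run of ring sizes and show whether the level stretch holds throughout. Morpholine would test whether a ring oxygen in place of a ring carbon is accepted in the six-membered ring.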